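The compounds below may be only part of what the source reports. "The series", "measured", "known", "first", "only" and "open" are said of these compounds alone.

Among the compounds with values here, compound 2 `COc1cc(-c2cc(/C=C/C(=O)c3ccc(Cl)c(Cl)c3)[nH]n2)cc(OC)c1OC` gives 33% in a functional assay on RPMI-8226 cells (Homo sapiens) for cytotoxicity, read by sulforhodamine B assay, with a stated time of 48 h, tested at 1 uM (a higher number here means a weaker effect of the compound at the concentration tested, a lower number a stronger effect), one of only two numbers measured so far. Compound 1 `COc1cc(-c2cc(/C=C/C(=O)c3ccc(N)cc3)[nH]n2)cc(OC)c1OC` gives 28% in this assay, within the scatter of compound 2. Compound 3 `COc1ccc(C(=O)/C=C/c2cc(-c3cc(OC)c(OC)c(OC)c3)n[nH]2)cc1OC` differs from compound 2 in one place: 3,4-dimethoxyphenyl in place of 3,4-dichlorophenyl on a carbonyl carbon. Within the data shown here, the single measured step, a number 5 percentage points higher from compound 1 to compound 2 (within the scatter), also exchanged the group on the carbonyl carbon and stayed within the scatter, which suggests that this position tolerates such swaps without a large change. The expectation for the step of a number 2 percentage points lower from compound 2 to compound 3 (within the scatter) is therefore nothing beyond the scatter. Compound 3 is expected to give about 31%, in a range from 15% to 50%.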

Compound 3, a percentage reported as activity, at one concentration (the size of the read-out at that concentration, not a potency): 2%
Compound 3: middle estimate off by 29 percentage points, on the high side, outside the stated range (below it).
By their numbers in this assay, from the lowest: compound 3; then compounds 1 and 2 (each within the scatter of the next).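

The position on the carbonyl carbon is less tolerant than the first pair suggested: in this assay, 3,4-dimethoxyphenyl stands apart from both earlier groups, with a number 31 percentage points lower from compound 2 to compound 3 (beyond the scatter) and a number 26 percentage points lower from compound 1 to compound 3 (beyond the scatter) as its two steps. The effect at the concentration tested is therefore stronger with this group, while 3,4-dichlorophenyl and 4-aminophenyl remain within the scatter of each other. Which group sits here can thus matter a great deal, although not every exchange does.

Going by these compounds, whether both methoxy groups are needed, and whether ethoxy groups or a carboxylic acid would give a similar number, remains open. Nothing available explains the change at this position.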